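Methoxy on the aromatic ring of the dithioacetal series

The source may hold more compounds than are shown below. What is called first, only, known or untested is meant among the compounds shown, and "the series" means these compounds.

Among the measured compounds shown here, compound 1 `CCCCCCCCCCCOc1ccccc1C(SCCC(=O)O)SCCC(=O)O` carries the only number recorded here: in an assay on membranes from lung (Cavia porcellus) for binding affinity to cysteinyl leukotriene receptor (Homo sapiens) (on this read-out higher numbers stand for weaker inhibition and lower numbers for stronger inhibition), compound 1 gives 287 nM. Compound 2 `O=C(O)CCSC(SCCC(=O)O)c1ccccc1OCCCCCCCCCO` reaches only the limit of this assay, at > 20000 nM. Compound 3 `CCCCCCCCCCCOc1ccccc1C(C)(SCCC(=O)O)SCCC(=O)O` likewise sits at the limit, > 20000 nM. Both measured steps are large losses: an at least 69-fold higher number from compound 1 to compound 2 (1.84 log units; beyond the scatter) and an at least 69-fold higher number from compound 1 to compound 3 (1.84 log units; beyond the scatter), each ending at the limit of > 20000 nM in this assay, at which 2 of the 3 values shown sit.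

Compound 4 `CCCCCCCCCCCOc1ccc(OC)cc1C(SCCC(=O)O)SCCC(=O)O` differs from compound 1 by methoxy in place of hydrogen on an aromatic carbon. Neither measured step touches the aromatic ring: one alters the end of the saturated chain, the other the carbon bearing the two sulfurs. They show that changes at those two places are not tolerated, but they say nothing about substitution on the ring itself, so no direction can be drawn from them for compound 4. With the chain and the dithioacetal carbon left as in compound 1, a step for compound 4 of at most modest size is expected, a 1.6-fold higher number from compound 1 to compound 4 (0.20 log units; within the scatter), with the uncertainty left open in both directions. Compound 4 is therefore estimated at 450 nM, within the range 100 nM to 3000 nM in this assay.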

Compound 4, inhibition constant: 579 nM
Compound 4: middle estimate off by 1.3-fold (0.11 log units), on the low side, and the stated range covers the measured number.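

Among the compounds shown here, compound 4 gives the first reading on substitution of the aromatic ring itself: methoxy on this aromatic carbon, meta to a large group and para to a large group, produces a 2.0-fold higher number from compound 1 to compound 4 (0.30 log units; within the scatter) in this assay. This step stays within the scatter, so this carbon accepts methoxy without a measurable loss, whereas the changes at the chain end and at the carbon bearing the two sulfurs each gave a large loss. No measured property shown here bears on this result.

One methoxy group at one ring carbon cannot show whether a larger or charged group, such as a carboxylic acid or an amine, would be accepted there as well. Also open, going by these compounds, is whether methoxy on the other free aromatic carbons, or combined with a shorter or longer chain, would leave binding similarly intact.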